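Swapping One Aromatic Ring in a Small Series

The compounds below may be only part of what the source reports. "The series", "measured", "known", "first", "only" and "open" are said of these compounds alone.

Three compounds share a core and differ only in one aromatic ring. In a functional assay on NCI-H226 cells (Homo sapiens) for inhibition, read by MTT assay, with a stated time of 48 h, tested at 10 uM (a higher number here means more inhibition at the concentration tested (going by the name of the read-out), a lower number less inhibition), compound 1 `COc1cc(Br)ccc1Nc1cc(NC(=O)Nc2c(Cl)cccc2Cl)ncn1` gives 43%, the second highest of the three numbers. Compound 3 `COc1cc(NC(=O)Nc2cc(Nc3cc(C)cc(F)c3)ncn2)cc(OC)c1` gives 35.3%, which lies within the scatter of compound 1, so the two cannot be told apart. Compound 2 `COc1cc(Nc2cc(NC(=O)Nc3c(Cl)cccc3Cl)ncn2)cc(OC)c1` gives 60%, a number beyond the scatter above compound 1. Compound 4 `O=C(Nc1cc(Nc2ccc(F)c(Cl)c2)ncn1)Nc1c(Cl)cccc1Cl` has not yet been measured in this assay; it differs from compound 1 by 3-chloro-4-fluorophenyl in place of 4-bromo-2-methoxyphenyl on a nitrogen on an aromatic ring. Within the data shown here, no measured step of this kind is available, so the expected step of a number 2 percentage points higher from compound 1 to compound 4 (within the scatter) is none beyond the scatter. Compound 4 is therefore estimated to give 45%, in a range from 25% to 65%.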

Compound 4, a percentage reported as inhibition, at one concentration (the size of the read-out at that concentration, not a potency): 47.3%
Beside the measured number, compound 4's estimate is 2.3 percentage points below it; the measured number falls inside the stated range.
By their numbers in this assay, from the lowest: compounds 3, 1 and 4 (each within the scatter of the next, the first and the last beyond it); then compound 2.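

Among these compounds, this is the first measured step at this position, the ring on a nitrogen on an aromatic ring: in this assay the change is a number 4.3 percentage points higher from compound 1 to compound 4 (within the scatter). So 4-bromo-2-methoxyphenyl can give way to 3-chloro-4-fluorophenyl, losing the methoxy group and the bromine, without a readable change in inhibition at the concentration tested. Nothing measured here says why the two rings read alike.

Going by these compounds, whether the chlorine and fluorine of the entering ring each matter stays open. So does whether a ring bearing an amine or a carboxylic acid, or a longer chain in place of the ring, would shift the number.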